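The source may hold more compounds than are shown below. What is called first, only, known or untested is meant among the compounds shown, and "the series" means these compounds.

Of the compounds shown here, three share one core and have been tested in a functional assay on MCF7 cells (Homo sapiens) for antiproliferative activity, read by MTT assay, with a stated time of 72 h; a lower number here means a stronger inhibitor, a higher number a weaker inhibitor. Compound 1 `Cc1cc(NCCN(C)C)nc2ccc(NC(=O)c3ccc(Cl)c(Cl)c3)cc12` gives 2550 nM in this assay. Among the measured compounds shown here, compound 3 `Cc1cc(N2CCCCC2)nc2ccc(NC(=O)c3ccc(Cl)c(Cl)c3)cc12` gives 31100 nM in this assay, and the single one-place change measured so far, a 12-fold higher number from compound 1 to compound 3 (1.09 log units; beyond the scatter), concerns the amine end of the core. Compound 2 `CCc1ccccc1C(=O)Nc1ccc2nc(N3CCN(CC)CC3)cc(C)c2c1` gives 15800 nM in this assay; among the three numbers it stands second highest, lying close to the number of compound 3 and clearly above the number of compound 1.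

Compound 4 `CCN1CCN(c2cc(C)c3cc(NC(=O)c4ccc(F)cc4)ccc3n2)CC1` has not yet been measured. It differs from compound 2 in one place: 4-fluorophenyl in place of 2-ethylphenyl on a carbonyl carbon. For the measured compounds named here, no measured step bears on this change, since the one recorded step, from compound 1 to compound 3, alters the amine rather than the amide. With nothing to point either way, compound 4 is expected to show no step beyond the scatter, an estimate of 12000 nM with a range from 3000 nM to 45000 nM. That estimate for compound 4 means a 1.3-fold lower number from compound 2 to compound 4 (0.12 log units; within the scatter).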

Compound 4, half-maximal inhibitory concentration: 4030 nM
For compound 4 the middle estimate is 3.0-fold (0.47 log units) above the measured one; low and high end bracket the measured number.
By their numbers in this assay, from the lowest: compounds 1 and 4 (each within the scatter of the next); then compounds 2 and 3 (each within the scatter of the next).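

Among the compounds shown here, until now the only measured step concerned the amine end of the core, and this result shows that the group on the amide carbonyl also counts in this assay. With the amine end held fixed, 4-fluorophenyl in place of 2-ethylphenyl on this carbonyl carbon gives a 3.9-fold lower number from compound 2 to compound 4 (0.59 log units; beyond the scatter), a modest step but one that clears the usual scatter, so this position responds to change as well. The data shown offer no measured explanation for this step.

Whether the loss of the ethyl group or the arrival of the fluorine accounts for the step remains open, as no compound shown carries a plain phenyl on this carbonyl. Also open, from the compounds shown here alone, is whether the same swap would give a similar step on a compound with the amine end of compound 1.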